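This account rests on a few compounds, and the source may have more. Where it says the series, first, only, none or still open, it means among the compounds named here.

Compound 1, `CC1(C)CCC[C@]2(C)[C@@H](CC[C@@](C)(O)/C=C/c3cccc([N+](=O)[O-])c3)[C@](C)(O)CC[C@@H]12`: 3400 nM
Compound 2, `CC1(C)CCC[C@]2(C)[C@@H](CC[C@@](C)(O)/C=C/c3cncc4ccccc34)[C@](C)(O)CC[C@@H]12`: 45700 nM

Both compounds were tested in a functional assay on A549 cells (Homo sapiens) for cytotoxicity, read by MTT assay, with a stated time of 48 h; a lower number here means a stronger inhibitor, a higher number a weaker inhibitor. Compound 1 has the lowest of the two numbers; the nearest, compound 2, shows a 13-fold higher number from compound 1 to compound 2 (1.13 log units; beyond the scatter). Compound 3, `CC(C)(C)c1ccc(/C=C/[C@](C)(O)CC[C@@H]2[C@@]3(C)CCCC(C)(C)[C@@H]3CC[C@@]2(C)O)cc1`, has not yet been measured. It differs from compound 1 in one place: 4-(tert-butyl)phenyl in place of 3-nitrophenyl on a double-bonded chain carbon bound to a double-bonded chain carbon. Going by the values given here, the only measured step that concerns the same place is a 13-fold higher number from compound 1 to compound 2 (1.13 log units; beyond the scatter), which exchanged the same group on the shared core for a different one and gave a large rise in the number, that is, a weaker inhibitor. Among the compounds with values here, the group entering in compound 3 is not the one in compound 2, so that step is only a loose guide; it shows that, so far, replacing the 3-nitrophenyl on this double-bonded chain carbon has only weakened the inhibitor. A moderate rise, smaller than that step, is therefore expected for compound 3, in the direction of a weaker inhibitor: a 2.1-fold higher number from compound 1 to compound 3 (0.31 log units; beyond the scatter). Compound 3 is estimated at 7000 nM, within a range from 2000 nM to 25000 nM.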

Compound 3, half-maximal inhibitory concentration: 45000 nM
The estimate for compound 3 lay 6.4-fold (0.81 log units) below the measured number, and the stated range ends below it.
By their numbers in this assay, from the lowest: compound 1; then compounds 3 and 2 (each within the scatter of the next).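

In this assay, a second replacement of the 3-nitrophenyl on this double-bonded chain carbon gives a 13-fold higher number from compound 1 to compound 3 (1.12 log units; beyond the scatter) and so also lands far from compound 1, which shows that the large rise seen with isoquinolin-4-yl was not unique to that group. The two replacements are very different groups, one holding a ring nitrogen and the other made of carbon only, yet they show a 1.0-fold lower number from compound 2 to compound 3 (0.01 log units; within the scatter) and cannot be told apart in this assay, while compound 1 keeps the lowest number of the three. No measurement of any property of these groups is available to explain this result.

The compounds shown leave open which part of the 3-nitrophenyl goes with the lower number, the nitro group or the phenyl ring that carries it. A plain phenyl on this carbon would help to separate the two, and a phenyl ring carrying an amine or a carboxylic acid would show whether any other group can match compound 1.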